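The source may report more compounds than this note shows. Statements on the series, on what has been measured and on what is new or still open speak of the compounds shown alone.

Compound 1 `CCOC(=O)NS(=O)(=O)c1sc(CC(C)C)cc1-c1cccc(Cn2ccnc2)c1` gives 300 nM in an assay on HEK293 cells for displacement of a labelled ligand from Type-2 angiotensin II receptor (Homo sapiens), read by scintillation counting, with a stated time of 240 min (a higher number here means a weaker inhibitor, a lower number a stronger inhibitor), and compound 2 `CCC(C)OC(=O)NS(=O)(=O)c1sc(CC(C)C)cc1-c1cccc(Cn2ccnc2)c1` gives 440 nM; the two numbers lie within the scatter of each other, as the step of a 1.5-fold higher number from compound 1 to compound 2 (0.17 log units; within the scatter) shows. Compound 3 `CCCC(=O)NS(=O)(=O)c1sc(CC(C)C)cc1-c1cccc(Cn2ccnc2)c1` differs from compound 1 in one place: propyl in place of ethoxy on a carbonyl carbon. The measured step concerns a different part of the molecule and bears only loosely on an exchange of ethoxycarbonyl for propylcarbonyl, so there is no direct guide. The step is expected to stay small, a 1.3-fold higher number from compound 1 to compound 3 (0.12 log units; within the scatter). Compound 3 is therefore estimated at 400 nM, within 150 nM to 1100 nM.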

Compound 3, inhibition constant: 300 nM
Compound 3: the middle estimate sits 1.3-fold (0.12 log units) above what was measured; the range from low to high includes it.
By their numbers in this assay, from the lowest: compounds 1, 3 and 2 (each within the scatter of the next).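

In this assay, within the data shown here, the earlier compounds varied only the chain on the oxygen, whereas compound 3 replaces the whole ethoxy group on the carbonyl carbon with the all-carbon propyl group, and the number holds (no change at the digits printed from compound 1 to compound 3 (within the scatter)). The comparison with the larger sec-butoxy group also stays within the scatter (a 1.5-fold lower number from compound 2 to compound 3 (0.17 log units; within the scatter)). Nothing available bears on why this exchange is tolerated. The compounds shown leave open whether an amine, or a chain much longer than propyl, on this carbonyl carbon would also hold the number in this assay.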